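Estimating an Isopropyl Aniline from Three Weak Neighbours

A few compounds are considered here, and "the series" means these few. Any claim that something is new, unique, unknown or untested is made for them only; others in the source may bear on it.

Measured compounds:
compound 1, `CNC(=O)c1ccccc1Oc1nc(Nc2ccc(Br)cc2)ncc1Br`, > 50000 nM
compound 2, `CNC(=O)c1ccccc1Oc1nc(Nc2cccc(C(F)(F)F)c2)ncc1Br`, 57800 nM
compound 3, `CNC(=O)c1ccccc1Oc1nc(Nc2cccc(OC)c2)ncc1Br`, 18200 nM

All three share one core and differ only in the aryl group on the nitrogen on an aromatic ring. In a functional assay on MCF7 cells (Homo sapiens) for antiproliferative activity, read by MTT assay, with a stated time of 24 h (on this read-out lower numbers stand for stronger inhibition and higher numbers for weaker inhibition), compound 1 reaches only a limit of the assay, > 50000 nM, so no number is known for it (the limit of > 50000 nM in this assay, at which 1 of the 3 values shown sits). Compound 2 gives 57800 nM and compound 3 gives 18200 nM. On the numbers shown compound 3 stands lowest, with an at least 2.7-fold lower number from compound 1 to compound 3 (0.43 log units; beyond the scatter) and a 3.2-fold lower number from compound 2 to compound 3 (0.50 log units; beyond the scatter) both beyond the scatter, and compound 1 sits at the weak end.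

Compound 4, `CNC(=O)c1ccccc1Oc1nc(Nc2cccc(C(C)C)c2)ncc1Br`, is not yet measured. Its difference from compound 1 is: 3-isopropylphenyl in place of 4-bromophenyl on a nitrogen on an aromatic ring. Within the data shown here, the one measured step that starts from compound 1 is an at least 2.7-fold lower number from compound 1 to compound 3 (0.43 log units; beyond the scatter), which likewise replaces the 4-bromophenyl. The step of a 3.2-fold lower number from compound 2 to compound 3 (0.50 log units; beyond the scatter) shows that the group on the new ring matters by a modest amount, and whether 3-isopropylphenyl behaves more like 3-methoxyphenyl or more like the trifluoromethyl-bearing ring of compound 2 cannot be read from these three compounds. For compound 4 the step of an at least 1.4-fold lower number from compound 1 to compound 4 (0.15 log units; that floor lies within the scatter) is therefore expected to be small, with a fair chance that only a limit is reported again. The estimate for compound 4 is 35000 nM, within a range from 12000 nM to 100000 nM.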

Compound 4, half-maximal inhibitory concentration: 26500 nM
Compound 4: middle estimate off by 1.3-fold (0.12 log units), on the high side, and the stated range covers the measured number.
By their numbers in this assay, from the lowest: compounds 3 and 4 (each within the scatter of the next); then compound 2.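

The step from trifluoromethyl to isopropyl on an aromatic carbon gives a 2.2-fold lower number from compound 2 to compound 4 (0.34 log units; beyond the scatter) in this assay, so methoxy is no longer the only group shown to stand apart from the trifluoromethyl of compound 2. Isopropyl and methoxy, in contrast, cannot be told apart, with a 1.5-fold higher number from compound 3 to compound 4 (0.16 log units; within the scatter), so among these compounds the oxygen-bearing methoxy can give way to an all-carbon isopropyl with no change beyond the scatter. The comparison with the 4-bromophenyl is less firm, with an at least 1.8-fold lower number from compound 1 to compound 4 (0.27 log units; that floor lies within the scatter), and this step gives only a floor, since the value for compound 1 is a limit of the assay and not a number: the limit of > 50000 nM in this assay, at which 1 of the 4 values shown sits.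

As far as these compounds go, how far compound 1 truly lies from the other compounds therefore stays unknown, and so does the question of whether its 4-bromophenyl differs from the other rings at all. The compounds shown also leave open whether an amine, a carboxylic acid or a longer chain such as a hexyl group on the aniline ring would move the number in this assay further than isopropyl or methoxy does.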